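Adding a Second Chloro Group to Compound 3

The source may report more compounds than this note shows. Statements on the series, on what has been measured and on what is new or still open speak of the compounds shown alone.

Compound 1 `Cc1ccc(-c2ccc(N3CCC(O)CC3)nn2)c(Cl)c1` gives 21 mg/kg in a functional assay on the whole organism with Mus musculus as the target, in the maximal electroshock model; on this read-out lower numbers stand for an effect already at smaller amounts and higher numbers for an effect only at larger amounts of compound.
Compound 2 `Cc1ccc(-c2ccc(N3CCC(O)CC3)nn2)cc1` gives 73 mg/kg in this assay.
Compound 3 `O=C1CCN(c2ccc(-c3ccccc3Cl)nn2)CC1` gives 40 mg/kg in this assay.

From compound 2 to compound 1 the step is a 3.5-fold lower number from compound 2 to compound 1 (0.54 log units; beyond the scatter), made by chloro in place of hydrogen on an aromatic carbon. The value of compound 3 lies within the scatter of both compound 1 and compound 2, and the difference between the core of compound 3 and the core of compound 2 is not broken down here. Compound 4 `O=C1CCN(c2ccc(-c3ccc(Cl)cc3Cl)nn2)CC1` is not yet measured; it arises from compound 3 by chloro in place of hydrogen on an aromatic carbon. This is the same kind of change as from compound 2 to compound 1, but the place is not the same: there the chloro entered ortho to a large group and meta to a methyl group, here meta to a chloro group and para to a large group. Because the earlier step was a 3.5-fold lower number from compound 2 to compound 1 (0.54 log units; beyond the scatter), a lowering is expected, though a more cautious one is estimated for compound 4 at a 1.8-fold lower number from compound 3 to compound 4 (0.26 log units; within the scatter). Compound 4 is therefore expected to give 22 mg/kg in this assay, estimated between 10 mg/kg and 50 mg/kg.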

Compound 4, dose for half-maximal effect: 5 mg/kg
For compound 4 the middle estimate is 4.4-fold (0.64 log units) above the measured one, outside the stated range (below it).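

Chloro in place of hydrogen gives an 8.0-fold lower number from compound 3 to compound 4 (0.90 log units; beyond the scatter) in this assay. Set beside the earlier step, the change lowers the number on both cores, and the two sizes cannot be told apart: the same change on two cores in this assay, a 3.5-fold lower number (0.54 log units; beyond the scatter) from compound 2 to compound 1 and an 8.0-fold lower number (0.90 log units; beyond the scatter) from compound 3 to compound 4, 2.3-fold (0.36 log units) apart, within the scatter of two such steps. For the compounds shown here, this rests on only two pairs, with the chloro in a different place in each, so it does not show that the change would carry to every core or to every place on the ring.

The compounds shown leave open whether a fluoro or a methoxy group in the same place, meta to a chloro group and para to a large group, would also lower the number. Also open, as far as these compounds go, is how the chloro step would read on a core carrying an amine in place of the carbonyl.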